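Iodo for fluoro in the thioamide sulfonamide series

The compounds below may be only part of what the source reports. "The series", "measured", "known", "first", "only" and "open" are said of these compounds alone.

Three compounds of this series have a number in a functional assay for antagonist activity at transient receptor potential cation channel subfamily V member 1 (Rattus norvegicus); a higher number here means a weaker inhibitor, a lower number a stronger inhibitor. Compound 1 `Cc1cc(CNC(=O)CCc2ccc(C(C)(C)C)cc2)cc(Cl)c1NS(C)(=O)=O`, the amide, gives 100 nM. Compound 2 `CC(C)(C)c1ccc(CCC(=S)NCc2ccc(NS(C)(=O)=O)c(F)c2)cc1`, a thioamide with fluoro ortho to the methanesulfonamido group, gives 40 nM. Compound 3 `CC(C)(C)c1ccc(CCC(=S)NCc2ccc(NS(C)(=O)=O)cc2Cl)cc1`, a thioamide with chloro instead, gives 3500 nM. Compound 2 stands at the lowest number of the three: compound 1 is a short way above it, beyond the scatter, and compound 3 lies far above it.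

Compound 4 `CC(C)(C)c1ccc(CCC(=S)NCc2ccc(NS(C)(=O)=O)c(I)c2)cc1` is not yet measured. It differs from compound 2 by iodo in place of fluoro on an aromatic carbon. Among the measured compounds shown here, no step between measured compounds isolates this exchange, so the direction rests on the halogen exchange alone. The expectation is a step from compound 2 to compound 4 of about a 1.5-fold higher number from compound 2 to compound 4 (0.18 log units; within the scatter), that is no change beyond the scatter, with a slight weakening more likely than a gain. Compound 4 is therefore estimated at 60 nM in this assay, in a range from 15 nM to 250 nM.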

Compound 4, half-maximal inhibitory concentration: 300 nM
The estimate for compound 4 lay 5.0-fold (0.70 log units) below the measured number; measured number above the stated range.
By their numbers in this assay, from the lowest: compound 2; then compound 1; then compound 4; then compound 3.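

In this assay, iodo in place of fluoro on this aromatic carbon, ortho to a methanesulfonamido group, gives a 7.5-fold higher number from compound 2 to compound 4 (0.88 log units; beyond the scatter), so this position does not treat the two halogens alike. The exchange leaves the counts of hydrogen-bond donors and acceptors and the net charge unchanged, yet the step lies beyond the scatter. No measurement shown here bears on the reason for this step.

Among the compounds shown here, only one pair isolates this exchange, so no trend across the halogens can be drawn, and whether bromo, methyl or methoxy on the same carbon would sit nearer compound 2 or compound 4 remains open. Also open, as far as these compounds go, is whether iodo in place of fluoro would give a step of similar size in an amide rather than a thioamide.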